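A Pyrimidine Swap on the Most Potent Sulfonamide

A few compounds are considered here, and "the series" means these few. Any claim that something is new, unique, unknown or untested is made for them only; others in the source may bear on it.

Three compounds sharing one sulfonamide-linked core were compared in a functional assay for agonist activity at growth hormone secretagogue receptor type 1 (Homo sapiens), read by FLIPR; a higher number here means that more compound is needed for the effect, a lower number that less compound is needed. Compound 1 `C[C@@H]1CN(c2cc(NS(=O)(=O)c3ccc(-c4ccccn4)s3)ccc2C#N)C[C@H](C)N1` gives 631 nM in this assay. Compound 2 `CCOc1ccc(N2C[C@@H](C)N[C@@H](C)C2)cc1NS(=O)(=O)c1ccc(-c2ccccn2)s1` gives 39.8 nM. Compound 3 `COc1ccc(N2C[C@@H](C)N[C@@H](C)C2)cc1NS(=O)(=O)c1ccc(-c2ccccc2)cc1` gives 6.31 nM, the lowest of the three numbers; its nearest neighbour is compound 2, its furthest is compound 1, and both gaps lie beyond the usual scatter, so compound 3 stands as the most potent of the measured set.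

Compound 4 `COc1ccc(N2C[C@@H](C)N[C@@H](C)C2)cc1NS(=O)(=O)c1ccc(-c2cncnc2)cc1` has not yet been measured. It differs from compound 3 in one place: pyrimidin-5-yl in place of phenyl on an aromatic carbon. For the measured compounds named here, no pair of measured compounds mirrors this exchange, so no step of the same kind can be read off the data, and the expectation rests on compound 3 alone. Compound 1 and compound 2 show only that other alterations of the shared core carry numbers well above that of compound 3.

For compound 4 a modest rise in the number is expected, so that the step of a 2.5-fold higher number from compound 3 to compound 4 (0.40 log units; beyond the scatter) is estimated as a small loss in this assay. Compound 4 is therefore estimated at 16 nM, with a range from 5 nM to 50 nM.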

Compound 4, half-maximal effective concentration: 316 nM
For compound 4 the middle estimate is 20-fold (1.30 log units) below the measured one; measured number above the stated range.
By their numbers in this assay, from the lowest: compound 3; then compound 2; then compounds 4 and 1 (each within the scatter of the next).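

For the compounds shown here, with phenyl on this aromatic carbon, compound 3 had set the low end of the series, and this assay now gives the first one-place step in the set: a 50-fold higher number from compound 3 to compound 4 (1.70 log units; beyond the scatter). The exchange keeps the same count of heavy atoms and a six-membered aromatic ring, with no net charge on either group, yet the ring changes from carbon only to one holding 2 hetero atoms and 2 hydrogen-bond acceptors, so this position, para to a large group, proves highly sensitive to a change of ring atoms alone. No measurement here gives an explanation for the size of this loss.

The compounds shown leave open whether a ring with a single nitrogen, or a phenyl ring carrying fluorine or an amine, would stay close to compound 3 at 6.31 nM or fall away as pyrimidin-5-yl does. With this single step, they also leave open which of the two ring nitrogens matters, or whether both do, and whether the same exchange would carry a step of similar size on another core.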